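The compounds below may be only part of what the source reports. "The series", "measured", "known", "first", "only" and "open" are said of these compounds alone.

Compound 1, `O=C(Nc1ccccc1)c1c(NCCO)cc(-c2cccc(Br)c2)oc1=O`: in an ADME assay on Huh-7 cells (Homo sapiens) for cytotoxicity, with a stated time of 3 days (a higher number here means that more compound is tolerated, a lower number that less compound is tolerated), compound 1 gives > 20000 nM, which is a limit of the assay and not a number.
Compound 2, `O=C(Nc1ccc(F)cc1)c1c(NCCO)cc(-c2cccc(Br)c2)oc1=O`: in this assay compound 2 gives > 20000 nM, again a limit of the assay.
Compound 3, `O=C(Nc1ccc(Cl)cc1)c1c(NCCO)cc(-c2cccc(Br)c2)oc1=O`: in this assay compound 3 gives 17000 nM.

Going by the values given here, compound 3 therefore holds the only number among the three values; the other two sit at the limit of > 20000 nM in this assay, at which 2 of the 3 values shown sit. Compound 4, `O=C(Nc1ccc(Br)cc1)c1c(NCCO)cc(-c2cccc(Br)c2)oc1=O`, differs from compound 3 in a single place: bromo in place of chloro on an aromatic carbon. Two measured steps speak to this kind of change, both putting chloro at that same place: an at least 1.1-fold lower number from compound 1 to compound 3 (0.07 log units; that floor lies within the scatter) and an at least 1.1-fold lower number from compound 2 to compound 3 (0.07 log units; that floor lies within the scatter). Both are only floors, and both lie within the scatter. The remaining pair gives a step that the two limits leave unreadable from compound 1 to compound 2, so it adds nothing readable. Exchanging one small group for another at this place has so far not moved the number beyond the scatter, and the step from compound 3 to compound 4 is expected to be a 1.1-fold lower number from compound 3 to compound 4 (0.05 log units; within the scatter) in this assay, with no clear direction. Compound 4 is thus estimated to give 15000 nM, with a range from 6000 nM to 30000 nM.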

Compound 4, half-maximal cytotoxic concentration: > 20000 nM
Compound 4 ended at the assay's limit (the forecaster's own chance of this, stated with the estimate: 35%); at least 1.3-fold (0.12 log units) between middle value and limit.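

With bromo in place of chloro on the aromatic carbon, this assay shows an at least 1.1-fold higher number from compound 3 to compound 4 (0.07 log units; that floor lies within the scatter). The earlier readable steps at this place were floors pointing toward a lower number, so this floor, pointing the other way, adds that swapping these two halogens has shown no change beyond the scatter in either direction. The steps among compounds 1, 2 and 4 cannot be read, and the set now presses against a single limit: the limit of > 20000 nM in this assay, at which 3 of the 4 values shown sit.

On these data alone, how far compounds 1, 2 and 4 lie past that limit stays open, so a real difference among them could be hidden. Also open, as far as these compounds go, is whether an amine, a carboxylic acid or a longer chain at this place would bring the number clearly down.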